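Swapping the sulfur-bearing group on compound 1

This account rests on a few compounds, and the source may have more. Where it says the series, first, only, none or still open, it means among the compounds named here.

Measured so far:
- compound 1, `CS(=O)(=O)Cc1cccc(C#Cc2cc(Cl)ccc2OCC(=O)O)c1`: 48 nM
- compound 2, `Cc1ccc(S(=O)(=O)NC(C)C)cc1C#Cc1cc(Cl)ccc1OCC(=O)O`: 3.4 nM

In an assay on CHO cells for displacement of a labelled ligand from prostaglandin D2 receptor 2 (Homo sapiens), read by scintillation counting (on this read-out higher numbers stand for weaker inhibition and lower numbers for stronger inhibition), compound 1 gives 48 nM, the higher of the two numbers measured. For the measured compounds named here, compound 2, which differs from it in several places at once, gives 3.4 nM, a gap beyond the usual scatter, but no single-change step links the two, so only the two values themselves can be compared.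

Compound 3, `C[S+]([O-])c1cccc(C#Cc2cc(Cl)ccc2OCC(=O)O)c1`, has not been measured yet. It differs from compound 1 at one place: a group of 3 heavy atoms (1 carbon, 1 oxygen, 1 sulfur; no ring) in place of a group of 5 heavy atoms (2 carbon, 2 oxygen, 1 sulfur; no ring), on an aromatic carbon. Going by the values given here, no measured pair shows what such a change does, so the direction can only be guessed. A modest shift toward a higher number, or none beyond the scatter, is expected, giving an estimated step of a 1.9-fold higher number from compound 1 to compound 3 (0.27 log units; within the scatter). Compound 3 is therefore expected to give about 90 nM, with a range of 25 nM to 320 nM.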

Compound 3, inhibition constant: 3.2 nM
Beside the measured number, compound 3's estimate is 28-fold (1.45 log units) above it; measured number below the stated range.
By their numbers in this assay, from the lowest: compounds 3 and 2 (each within the scatter of the next); then compound 1.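

In this assay, replacing the (methylsulfonyl)methyl group with the smaller sulfur-bearing group gives a 15-fold lower number from compound 1 to compound 3 (1.18 log units; beyond the scatter), so what sits at this place on the aromatic ring has a large effect on the number. It also shows that the full (methylsulfonyl)methyl group is not needed for strong inhibition, since the entering group has fewer heavy atoms and fewer hydrogen-bond acceptors. No available data explain why this single change has so large an effect.

Size and acceptor count change together in this one step, so the compounds shown cannot tell which of the two matters, or whether both do. On these data alone, it also remains open whether an amine or a nitrile at the same place would give a lower or a higher number.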